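The source may hold more compounds than are shown below. What is called first, only, known or untested is meant among the compounds shown, and "the series" means these compounds.

Compound 1 `N#Cc1c(NS(=O)(=O)c2ccccc2[N+](=O)[O-])[n+]([O-])c2ccc(Cl)cc2[n+]1[O-]` gives 6800 nM in an ADME assay on cells (Peritoneal macrophage cell, Mus musculus) for cytotoxicity, read by trypan blue exclusion, with a stated time of 48 h; on this read-out higher numbers stand for lower toxicity in this test and lower numbers for higher toxicity in this test.
Compound 2 `N#Cc1c(NS(=O)(=O)c2ccc([N+](=O)[O-])cc2)[n+]([O-])c2ccccc2[n+]1[O-]` gives "not determined" (no result reported) in this assay.
Compound 3 `CC(=O)Oc1ccccc1C(=O)Nc1c(C#N)[n+]([O-])c2ccccc2[n+]1[O-]` gives "not determined" (no result reported) in this assay.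

Compound 3 stands without a number in this assay, and compound 2 likewise has none; only compound 1 carries a value, which in this assay is 6800 nM. Compound 4 `CC(=O)Oc1ccccc1C(=O)Nc1c(C#N)[n+]([O-])c2cc(C)ccc2[n+]1[O-]` differs from compound 3 by methyl in place of hydrogen on an aromatic carbon. Within the data shown here, no step between measured compounds is recorded, so nothing here shows how such a change moves the read-out; the expected step in this assay is none beyond the scatter, in neither direction. Among the measured compounds shown here, compound 4 is therefore expected to land near the one number available, at about 7000 nM, within 2000 nM to 25000 nM.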

Compound 4, half-maximal cytotoxic concentration: 21700 nM
Compound 4: the middle estimate sits 3.1-fold (0.49 log units) below what was measured, within the range that was stated.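

In this assay, among these compounds, compound 3 has no single number, so no step to compound 4 can be read. The compounds shown leave open how methyl in place of hydrogen moves this read-out, and no evidence on the result is at hand.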